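This account rests on a few compounds, and the source may have more. Where it says the series, first, only, none or still open, it means among the compounds named here.

Working notes on the series, read in a functional assay on A549 cells (Homo sapiens) for antiproliferative activity, read by MTT assay, with a stated time of 48 h; a lower number here means a stronger inhibitor, a higher number a weaker inhibitor. Compound 1 `CCn1c(=O)n(-c2cc(OC)c(OC)c(OC)c2)c2cc(-c3ccc(OC)c(O)c3)ncc21` carries ethyl on the aromatic nitrogen and gives > 20000 nM, which is a limit of the assay and not a number. Compound 2 `COc1ccc(-c2cc3c(cn2)n(C2CC2)c(=O)n3-c2cc(OC)c(OC)c(OC)c2)cc1O` carries cyclopropyl there and gives > 20000 nM, again only a limit. For the measured compounds named here, compound 2 therefore has no readable standing, and the same holds for the one other value. Going by the values given here, the only measured change at this nitrogen is a step that the two limits leave unreadable from compound 1 to compound 2, and the series so far amounts to the limit of > 20000 nM in this assay, at which 2 of the 2 values shown sit.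

The next change leads to compound 3 `COc1ccc(-c2cc3c(cn2)n(CC(N)=O)c(=O)n3-c2cc(OC)c(OC)c(OC)c2)cc1O`, with carbamoylmethyl in place of cyclopropyl on an aromatic nitrogen. Among the compounds with values here, the measured step offers no size to carry over, so no step of definite size or direction is expected in this assay, and a further reading at the limit is the likeliest outcome. For compound 3 the expected value is 25000 nM, with an estimated range of 10000 nM to 60000 nM. The estimate corresponds to an expected step that the limit leaves unreadable from compound 2 to compound 3, which remains tentative while both measured values are limits.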

Compound 3, half-maximal inhibitory concentration: 10900 nM
Estimate against measurement, compound 3: 2.3-fold (0.36 log units) above; the measured number falls inside the stated range.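

In this assay, this position now gives a reading that is a number and not a limit: carbamoylmethyl in place of cyclopropyl on the aromatic nitrogen gives an at least 1.8-fold lower number from compound 2 to compound 3 (0.26 log units; that floor lies within the scatter), and carbamoyl in place of methyl on the saturated chain carbon bound to that nitrogen gives an at least 1.8-fold lower number from compound 1 to compound 3 (0.26 log units; that floor lies within the scatter). Both steps are floors that lie within the scatter, so the change from a limit to a number does not by itself establish a real gain, while the step between the two compounds at the limit cannot be read. The readings so far therefore show only that the carbamoylmethyl group, with its hydrogen-bond donor and acceptor, keeps the shared core within the measurable range, and most of the series remains at the limit: the limit of > 20000 nM in this assay, at which 2 of the 3 values shown sit.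

Going by these compounds, how far compound 1 and compound 2 lie beyond their limits remains open, and with it the true size of both steps. Also open, on these data alone, is whether a carboxylic acid, an amine or a longer chain on this nitrogen would move the number any further.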